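Compound 3: one added group on compound 2

This account rests on a few compounds, and the source may have more. Where it says the series, first, only, none or still open, it means among the compounds named here.

Values so far in an ADME assay, in phosphate buffer, at 37 degrees C, at pH 7.4; a lower number here means that the compound disappears faster, a higher number that the compound lasts longer
Compound 1 `CC1=C(CCCCCC(=O)OCOC(=O)C(C)(C)C)C(=O)c2ccccc2C1=O` gives 2 h
Compound 2 `COC(=O)CCCCCC1=C(C)C(=O)c2ccccc2C1=O` gives 1 h

Compound 2 stands within the usual scatter of compound 1, so these two values cannot be told apart. Compound 3 `CCCC(=O)OCOC(=O)CCCCCC1=C(C)C(=O)c2ccccc2C1=O` has not been measured. It carries (propylcarbonyl)oxy in place of hydrogen on a saturated chain carbon bound to an oxygen next to a carbonyl group. Among the compounds with values here, one measured step bears on this change, at the same place: a 2.0-fold lower number from compound 1 to compound 2 (0.30 log units; within the scatter). Read in reverse, it suggests little change in this assay. The expected step is a 1.5-fold higher number from compound 2 to compound 3 (0.18 log units; within the scatter), which stays within the scatter. Compound 3 is estimated at 1.5 h (expected range 0.7 h to 3.5 h)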

Compound 3, half-life: 1 h
Compound 3: the middle estimate sits 1.5-fold (0.18 log units) above what was measured; low and high end bracket the measured number.
By their numbers in this assay, from the lowest: compounds 2, 3 and 1 (each within the scatter of the next).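

In this assay, placing (propylcarbonyl)oxy on the saturated chain carbon bound to an oxygen next to a carbonyl group gives no change at the digits printed from compound 2 to compound 3 (within the scatter) and so adds nothing readable to the small methyl ester. Propyl in place of tert-butyl on a carbonyl carbon gives a 2.0-fold lower number from compound 1 to compound 3 (0.30 log units; within the scatter) and so shows that swapping these two groups also stays inside normal repeat variation. No measured evidence is available to explain these results. As far as these compounds go, whether an amine or a carboxylic acid on this carbon, or a longer chain in place of propyl, would move the half-life beyond the scatter remains open.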